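The source may hold more compounds than are shown below. What is called first, only, known or untested is meant among the compounds shown, and "the series" means these compounds.

Measured so far:
- compound 1, `CC1(C)Cc2c(sc(NC(=O)c3cccnc3O)c2C(N)=O)C(C)(C)O1`: 190 nM
- compound 2, `CC1(C)Cc2c(sc(NC(=O)C3(O)CC3)c2C(N)=O)C(C)(C)O1`: 23 nM

In an assay on cells for positive allosteric modulation of Cystic fibrosis transmembrane conductance regulator variant F508del (Homo sapiens), with stated times of 10 min and 7 s, in the presence of a further agent that is not named here (a higher number here means that more compound is needed for the effect, a lower number that less compound is needed), compound 1 gives 190 nM, the highest of the two numbers available; its nearest neighbour is compound 2, which gives 23 nM, a step of an 8.3-fold lower number from compound 1 to compound 2 (0.92 log units; beyond the scatter). Compound 3, `Cc1cc(C(=O)Nc2sc3c(c2C(N)=O)CC(C)(C)OC3(C)C)[nH]n1`, differs from compound 1 in one place: 3-methyl-1H-pyrazol-5-yl in place of 2-hydroxypyridin-3-yl on a carbonyl carbon. For the measured compounds named here, only one measured step bears on this change, and it shares the leaving group: exchanging the same 2-hydroxypyridin-3-yl for 1-hydroxycyclopropyl gave an 8.3-fold lower number from compound 1 to compound 2 (0.92 log units; beyond the scatter). The entering groups are not the same, so the earlier step guides the direction more than the size. A lower number than for compound 1 is therefore expected, though with less certainty than that single step alone would suggest. Compound 3 is estimated at 60 nM, with a range of 20 nM to 180 nM. The expected step is a 3.2-fold lower number from compound 1 to compound 3 (0.50 log units; beyond the scatter).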

Compound 3, half-maximal effective concentration: 13 nM
Estimate against measurement, compound 3: 4.6-fold (0.66 log units) above; measured number below the stated range.
By their numbers in this assay, from the lowest: compounds 3 and 2 (each within the scatter of the next); then compound 1.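

In this assay, the step of a 15-fold lower number from compound 1 to compound 3 (1.16 log units; beyond the scatter) shows that the low number seen with 1-hydroxycyclopropyl on this carbonyl carbon does not depend on that group: an aromatic ring can also give it, provided it is the five-membered 3-methyl-1H-pyrazol-5-yl rather than the six-membered 2-hydroxypyridin-3-yl. The entering group carries no oxygen, so among these compounds a hydroxy group is not needed for a low number. The two replacements cannot be told apart, with a 1.8-fold lower number from compound 2 to compound 3 (0.25 log units; within the scatter).

No measurement shown here explains why the pyrazole differs so much from the hydroxypyridine. The compounds shown leave open what the methyl on the pyrazole contributes, and whether a plain phenyl, an unsubstituted pyrazol-5-yl or a 1-aminocyclopropyl at this place would give a similar number.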